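Hydroxymethyl added to the ethyl amide of compound 3

A few compounds are considered here, and "the series" means these few. Any claim that something is new, unique, unknown or untested is made for them only; others in the source may bear on it.

Measured in a physicochemical assay for solubility; a lower number here means a less soluble compound, a higher number a more soluble compound:
- compound 1 `CCCNC(=O)c1cc(C(=O)NC)nn1[C@@H](C)c1ccccc1` gives >= 132 ug/mL as a limit
- compound 2 `CNC(=O)c1cc(C(=O)NC2CCOCC2)n([C@@H](C)c2ccccc2)n1` gives 31 ug/mL as a number
- compound 3 `CCNC(=O)c1cc(C(=O)NC)nn1[C@@H](C)c1ccccc1` gives >= 137 ug/mL as a limit

For compound 3 the reading >= 137 ug/mL is a limit and not a number, so the starting point of this step is open on its upper side. Compound 4 `CNC(=O)c1cc(C(=O)NC(C)CO)n([C@@H](C)c2ccccc2)n1` differs from compound 3 by hydroxymethyl in place of hydrogen on a saturated chain carbon bound to an amide-type nitrogen and a saturated chain carbon, which turns ethyl into 1-(hydroxymethyl)ethyl.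

Two measured steps change the group on that amide-type nitrogen: an at least 4.2-fold lower number from compound 1 to compound 2 (0.62 log units; beyond the scatter) and an at least 4.4-fold higher number from compound 2 to compound 3 (0.64 log units; beyond the scatter). Both lie beyond the scatter and both involve oxan-4-yl, not hydroxymethyl. The remaining step, a step that the two limits leave unreadable from compound 1 to compound 3, gives no readable size. Among the measured compounds shown here, compound 2 at 31 ug/mL shows that a change of this group can lower the number, and it is the only real number in the set.

The expected result for this change is an at least 1.2-fold lower number from compound 3 to compound 4 (0.09 log units; that floor lies within the scatter), with any real move more likely downward. For compound 4 the estimate is 110 ug/mL, with an expected range from 40 ug/mL to 200 ug/mL in this assay.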

Compound 4, solubility: >= 132 ug/mL
Compound 4 was reported as a limit (the forecaster's own chance of this, stated with the estimate: 45%); middle value at least 1.2-fold (0.07 log units) away from the limit.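

In this assay compound 4 gives >= 132 ug/mL, which is a limit. With 1-(hydroxymethyl)ethyl in place of oxan-4-yl on the amide-type nitrogen, the result is an at least 4.2-fold higher number from compound 2 to compound 4 (0.62 log units; beyond the scatter), so a branched group on this nitrogen that carries hydroxymethyl does not share the measured reading of compound 2. The steps to compound 4 from compound 1 and from compound 3 cannot be read, because both ends of each are limits: the limit of >= 132 ug/mL in this assay, at which 2 of the 4 values shown sit.

Going by these compounds, the true size of any difference among compound 1, compound 3 and compound 4 stays open, as does whether hydroxymethyl on this saturated chain carbon changes the reading at all. Also open, on these data alone, is how a carboxylic acid, an amine or a longer chain ending in hydroxyl at this position would read in this assay.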